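Bromo for Chloro on the Formyl-Bearing Compound

The compounds below may be only part of what the source reports. "The series", "measured", "known", "first", "only" and "open" are said of these compounds alone.

So far, three members of the series have been tested in a functional assay on the whole organism (strain Wistar albino) for inhibition, with Rattus norvegicus as the target, read by paw edema, with a stated time of 3 h, at a dose of 100 mg/kg by the oral route; on this read-out higher numbers stand for more inhibition at the one dose given (going by the name of the read-out) and lower numbers for less inhibition:

compound 1 `Cc1ccc2c(Cc3nn4cc(-c5ccc(Cl)cc5)nc4s3)coc2c1` — 51.7%
compound 2 `Cc1ccc2c(Cc3nn4cc(-c5ccc(Br)cc5)nc4s3)coc2c1` — 10.9%
compound 3 `Cc1ccc2c(Cc3nn4c(C=O)c(-c5ccc(Cl)cc5)nc4s3)coc2c1` — 42.5%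

Compound 3 holds the second highest of the three numbers. Its nearest neighbour is compound 1: the step of a number 9.2 percentage points lower from compound 1 to compound 3 (within the scatter) lies within the scatter, so the two cannot be ordered. Compound 2 is the furthest away, and the gap between compound 3 at 42.5% and compound 2 at 10.9% is beyond the scatter.

Compound 4 `Cc1ccc2c(Cc3nn4c(C=O)c(-c5ccc(Br)cc5)nc4s3)coc2c1` is the next compound for this assay. It differs from compound 3 as follows: bromo in place of chloro on an aromatic carbon.

Within the data shown here, one measured step bears on this change, the same exchange made on the compound without the formyl group: a number 40.8 percentage points lower from compound 1 to compound 2 (beyond the scatter), a large drop. Nothing in the data shows the formyl-bearing pair behaving otherwise, so a step of similar size and direction is expected in this assay, namely a number 34.5 percentage points lower from compound 3 to compound 4 (beyond the scatter). Compound 4 is therefore estimated at 8%, with a range from 0% to 28%.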

Compound 4, a percentage reported as inhibition, in the whole organism at one dose (the size of the read-out at that dose, not a potency): 10.9%
Estimate against measurement, compound 4: 2.9 percentage points below; the range from low to high includes it.
By their numbers in this assay, from the lowest: compounds 2 and 4 (each within the scatter of the next); then compounds 3 and 1 (each within the scatter of the next).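

In this assay, the 4-chlorophenyl to 4-bromophenyl exchange now reads on a second core: with the formyl group in place it gives a number 31.6 percentage points lower from compound 3 to compound 4 (beyond the scatter). The loss on bromo is therefore not confined to the core of compound 1, and its size carries over between the two cores: the same change on two cores in this assay, a number 40.8 percentage points lower (beyond the scatter) from compound 1 to compound 2 and a number 31.6 percentage points lower (beyond the scatter) from compound 3 to compound 4, 9.2 percentage points apart, within the scatter of two such steps The formyl group makes no step beyond the scatter with either halogen, since the bromo pair shows no change at the digits printed from compound 2 to compound 4 (within the scatter), and the two formyl steps agree: the same change on two cores in this assay, a number 9.2 percentage points lower (within the scatter) from compound 1 to compound 3 and no change at the digits printed (within the scatter) from compound 2 to compound 4, 9.2 percentage points apart, within the scatter of two such steps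

From the compounds shown here alone, both halogen pairs cover only chloro and bromo at this place on the six-membered aromatic ring, so it stays open whether fluoro, methoxy or an amine there would read with the chloro compounds or the bromo compounds. Going by these compounds, it also stays open whether a carboxylic acid or a longer chain in place of the formyl group would read apart from hydrogen.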